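Cytotoxicity limits around a shared core with benzyl changes

The source may hold more compounds than are shown below. What is called first, only, known or untested is meant among the compounds shown, and "the series" means these compounds.

Of the compounds shown here, three built on the same core have been tested in an ADME assay on MT4 cells (Homo sapiens) for cytotoxicity, read by MTT assay, with a stated time of 4 days; a higher number here means that more compound is tolerated, a lower number that less compound is tolerated. Compound 1, `CCOC(=O)c1cnc(N2CCN(Cc3ccc(F)cc3)CC2)nc1Oc1c(C)cc(-c2ccc(C#N)cc2)cc1C`, gives > 117000 nM in this assay, which is a limit of the measurement rather than a number. Compound 2, `CCOC(=O)c1cnc(N2CCN(Cc3ccccc3F)CC2)nc1Oc1c(C)cc(-c2ccc(C#N)cc2)cc1C`, gives > 125000 nM, again a limit. Compound 3, `CCOC(=O)c1cnc(N2CCN(Cc3ccc(S(N)(=O)=O)cc3)CC2)nc1Oc1c(C)cc(-c2ccc(C#N)cc2)cc1C`, gives >= 7930 nM, also a limit. Among the measured compounds shown here, compound 1 therefore stands on a limit only, and the two other values shown are limits as well, so no compound can be ranked against another. The steps among them confirm this: a step that the two limits leave unreadable from compound 1 to compound 2, a step that the two limits leave unreadable from compound 1 to compound 3 and a step that the two limits leave unreadable from compound 2 to compound 3.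

Compound 4, `CCOC(=O)c1ccc(CN2CCN(c3ncc(C(=O)OCC)c(Oc4c(C)cc(-c5ccc(C#N)cc5)cc4C)n3)CC2)cc1`, is not yet measured. It differs from compound 1 by ethoxycarbonyl in place of fluoro on an aromatic carbon. For the measured compounds named here, three measured steps bear on it in a loose sense, all of them changing the group on the same benzyl position, and none of them could be read as a size, since every value sits at a limit (the limit of > 117000 nM in this assay, at which 1 of the 3 values shown sits, (the limit of > 125000 nM in this assay, at which 1 of the 3 values shown sits), (the limit of >= 7930 nM in this assay, at which 1 of the 3 values shown sits)). No direction can be drawn from them. The expectation for compound 4 is therefore a step of about an at least 1.0-fold lower number from compound 1 to compound 4 (0.02 log units; that floor lies within the scatter), and its value in this assay is estimated at 110000 nM, within a range from 35000 nM to 250000 nM, most likely again reported only as a limit.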

Compound 4, half-maximal cytotoxic concentration: > 125000 nM
Compound 4 was reported as a limit (the forecaster's own chance of this, stated with the estimate: 80%); middle value at least 1.1-fold (0.05 log units) away from the limit.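

Compound 4 is again reported only as a limit in this assay, and with all four values being limits, its steps to compound 1, compound 2 and compound 3 cannot be read. The compounds shown leave open whether any of these benzyl changes alters the concentration tolerated, and by how much.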